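Methylcarbamoyl in place of 4-(trifluoromethoxy)phenyl: compound 3

The source may hold more compounds than are shown below. What is called first, only, known or untested is meant among the compounds shown, and "the series" means these compounds.

In an ADME assay on HeLa cells (Homo sapiens) for cytotoxicity, read by crystal violet staining, with a stated time of 72 h (a lower number here means that less compound is tolerated, a higher number that more compound is tolerated), compound 1 `COc1ccc(-c2cc(CCCOc3c(C)cc(-c4noc(C(F)(F)F)n4)cc3C)on2)cc1OC` gives 41900 nM as a measured number. Compound 2 `Cc1cc(-c2noc(C(F)(F)F)n2)cc(C)c1OCCCc1cc(-c2ccc(OC(F)(F)F)cc2)no1` gives > 100000 nM, which is a limit of the assay and not a number. For the measured compounds named here, the only measured step, an at least 2.3-fold higher number from compound 1 to compound 2 (0.37 log units; beyond the scatter), exchanges one substituted phenyl for another and bears only loosely on compound 3 `CNC(=O)c1cc(CCCOc2c(C)cc(-c3noc(C(F)(F)F)n3)cc2C)on1`, which has no such ring at this place: methylcarbamoyl in place of 4-(trifluoromethoxy)phenyl on an aromatic carbon. Going by the values given here, with compound 1 at 41900 nM as the only number, a modest fall in this assay is expected, and the estimated step is an at least 1.2-fold lower number from compound 2 to compound 3 (0.09 log units; that floor lies within the scatter). Compound 3 is expected at 80000 nM, with an estimated range of 30000 nM to 200000 nM.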

Compound 3, half-maximal cytotoxic concentration: > 100000 nM
Compound 3: a limit, no number; the forecaster's own chance of this, stated with the estimate: 50%; middle value at least 1.2-fold (0.09 log units) away from the limit.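

Methylcarbamoyl in place of 3,4-dimethoxyphenyl gives an at least 2.3-fold higher number from compound 1 to compound 3 (0.37 log units; beyond the scatter) in this assay, so a phenyl ring at this place is not required for the tolerance seen with compound 2. Compound 3 gives > 100000 nM, which is a limit of the assay and not a number. The step from compound 2 to compound 3 cannot be read, and comparison in this series stops at: the limit of > 100000 nM in this assay, at which 2 of the 3 values shown sit.

Any order between compound 2 and compound 3 stays open. Also open, on these data alone, is how a carboxylic acid, an amine or a longer amide chain at this place would read in this assay.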